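Trimethoxyphenyl triazoles without measurable antiproliferative effect

The source may report more compounds than this note shows. Statements on the series, on what has been measured and on what is new or still open speak of the compounds shown alone.

Compound 1 `COc1cc(-n2ncnc2-c2ccc(Cl)cc2)cc(OC)c1OC` and compound 2 `COc1cc(-n2ncnc2-c2ccc(Cl)c(Cl)c2)cc(OC)c1OC` share one core and were tested in a functional assay on K562 cells (Homo sapiens) for antiproliferative activity, read by MTT assay, with a stated time of 72 h; a lower number here means a stronger inhibitor, a higher number a weaker inhibitor. In this assay compound 1 gives only a limit, > 10000 nM. In this assay compound 2 likewise gives only a limit, > 10000 nM. The change from compound 2 to compound 1 is hydrogen in place of chloro on an aromatic carbon, and the step it made is a step that the two limits leave unreadable from compound 2 to compound 1. Compound 3 `COc1cc(-c2ncnn2-c2ccc(Cl)cc2)cc(OC)c1OC` carries a different core; the difference between the two cores is not broken down here. In this assay compound 3 gives only a limit, > 10000 nM. Among the compounds with values here, every measured value so far rests at the same boundary, namely (the limit of > 10000 nM in this assay, at which 3 of the 3 values shown sit).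

Compound 4 `COc1cc(-c2ncnn2-c2ccccc2)cc(OC)c1OC` has not yet been measured in this assay. Within the data shown here, its change from compound 3 is hydrogen in place of chloro on an aromatic carbon, a change of the same kind as the one from compound 2 to compound 1 but not the same, since in compound 2 the leaving chloro is ortho to a chloro group and meta to a large group, whereas in compound 3 it is para to a large group. Because all measured values sit at the limit of > 10000 nM in this assay, at which 3 of the 3 values shown sit, the size of the earlier step cannot be read, and no change shown here is known to move a compound off that boundary. Compound 4 is therefore expected to stay near the same limit, with an estimated step that the limit leaves unreadable from compound 3 to compound 4. The estimate for compound 4 in this assay is 20000 nM, expected to lie between 5000 nM and 100000 nM.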

Compound 4, half-maximal inhibitory concentration: > 10000 nM
Compound 4 was reported as a limit; the forecaster's own chance of this, stated with the estimate: 85%; the middle value is on the limit's open side.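

In this assay compound 4 gives > 10000 nM, which is a limit and not a number. Within the data shown here, compound 3 also stands at a limit, so the change from 4-chlorophenyl to phenyl between compound 3 and compound 4 gives no step that can be read, and the boundary stays shared: the limit of > 10000 nM in this assay, at which 4 of the 4 values shown sit. The compounds shown leave open whether chloro or hydrogen at this place matters at all, and which change, if any, would move a compound off that limit.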